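The compounds below may be only part of what the source reports. "The series", "measured", "known", "first", "only" and "open" are said of these compounds alone.

Measured compounds:
compound 1 `COc1ccc(-n2ccc(=O)c(C(=O)Nc3ccc(Oc4ccnc5[nH]ccc45)cc3)n2)cc1` — 21600 nM in a functional assay on MCF7 cells (Homo sapiens) for cytotoxicity, read by MTT assay, with a stated time of 72 h; on this read-out lower numbers stand for stronger inhibition and higher numbers for weaker inhibition
compound 2 `O=C(Nc1ccc(Oc2ccnc3[nH]ccc23)c(F)c1)c1nn(-c2ccc(Cl)cc2)ccc1=O` — > 60000 nM in this assay

Compound 2 `O=C(Nc1ccc(Oc2ccnc3[nH]ccc23)c(F)c1)c1nn(-c2ccc(Cl)cc2)ccc1=O` stands at a limit of this assay: its result, > 60000 nM, is a limit of the assay and not a number, the point described in the limit of > 60000 nM in this assay, at which 1 of the 2 values shown sits. Compound 1 `COc1ccc(-n2ccc(=O)c(C(=O)Nc3ccc(Oc4ccnc5[nH]ccc45)cc3)n2)cc1`, the other measured compound, gives a number in this assay, 21600 nM.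

Compound 3 `COc1ccc(-n2ccc(=O)c(C(=O)Nc3ccc(Oc4ccnc5[nH]ccc45)c(F)c3)n2)cc1` has not yet been measured. It differs from compound 2 by one change, (methoxy in place of chloro on an aromatic carbon), methoxy in place of chloro on an aromatic carbon. For the measured compounds named here, no measured pair shows this change on its own, so the size of the step cannot be read from the data. The expectation for compound 3 leans on compound 1, which in this assay gives 21600 nM. Compound 3 is therefore expected to sit near that number, with the step of an at least 1.7-fold lower number from compound 2 to compound 3 (0.23 log units; that floor lies within the scatter) estimated as a move from the limit toward a measurable value, and the estimate for compound 3 is 35000 nM, ranging from 12000 nM to 100000 nM.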

Compound 3, half-maximal inhibitory concentration: 55400 nM
Compound 3: the middle estimate sits 1.6-fold (0.20 log units) below what was measured; the range from low to high includes it.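

In this assay, for the compounds shown here, fluoro in place of hydrogen on an aromatic carbon gives a 2.6-fold higher number from compound 1 to compound 3 (0.41 log units; beyond the scatter), so this is the first change here whose size can be read and it lies beyond the usual scatter. The change from 4-chlorophenyl to 4-methoxyphenyl gives an at least 1.0-fold lower number from compound 2 to compound 3 (0.03 log units; that floor lies within the scatter), and that floor lies within the scatter, so the data do not establish that this change moves the number in either direction. Compound 2 gives a limit and not a number: the limit of > 60000 nM in this assay, at which 1 of the 3 values shown sits.

Going by these compounds, it remains open how an amine or a carboxylic acid on the same aromatic carbon would compare with methoxy and chloro. On these data alone, it also remains open whether the fluoro step would be the same size alongside the 4-chlorophenyl group.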